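A Chlorine for a Methyl on the Aniline Arm

The source may hold more compounds than are shown below. What is called first, only, known or untested is meant among the compounds shown, and "the series" means these compounds.

Two compounds of this series have a measured number or a limit. For the measured compounds named here, compound 1 `COc1cc(/C=C/C(=O)c2sc(Nc3ccccc3C)nc2C)cc(OC)c1OC` is the only one with a full value: in a functional assay on Bel-7402 cells (Homo sapiens) for cytotoxicity, read by MTT assay (a lower number here means a stronger inhibitor, a higher number a weaker inhibitor), compound 1 gives 10300 nM. Compound 2 `Cc1ccc(Nc2nc(C)c(C(=O)/C=C/c3ccc(Cl)cc3)s2)cc1` sits at a limit of the assay rather than at a number; in this assay compound 2 gives > 25000 nM. That limit is described by the limit of > 25000 nM in this assay, at which 1 of the 2 values shown sits. Going by the values given here, no step between two measured compounds is available, since compound 2 differs from compound 1 in more than one place.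

Compound 3 `COc1cc(/C=C/C(=O)c2sc(Nc3ccc(Cl)cc3)nc2C)cc(OC)c1OC` is still to be measured. It differs from compound 1 in one place only, (4-chlorophenyl in place of 2-methylphenyl on a nitrogen on an aromatic ring). Nothing measured here shows how this assay answers to that change. The step from compound 1 to compound 3 is therefore expected to be small, a 1.3-fold lower number from compound 1 to compound 3 (0.11 log units; within the scatter), within or only slightly beyond the usual scatter, and with no sure direction. For compound 3 the expected value in this assay is 8000 nM, with a plausible range from 2500 nM to 25000 nM, and some chance that only a limit is returned.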

Compound 3, half-maximal inhibitory concentration: > 25000 nM
Compound 3 gave a limit, no number; the forecaster's own chance of this, stated with the estimate: 20%; at least 3.1-fold (0.49 log units) between middle value and limit.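

For the compounds shown here, until this result, nothing showed how this assay answers to a change on the aniline arm. Putting 4-chlorophenyl in place of 2-methylphenyl on the nitrogen gives an at least 2.4-fold higher number from compound 1 to compound 3 (0.38 log units; beyond the scatter), so this position is not indifferent to the change, and the swap costs activity in these cells. The reading for compound 3, > 25000 nM, is a limit and not a number, so the step gives only the smallest size the loss can have, and compound 1 remains the only compound here with a full value: the limit of > 25000 nM in this assay, at which 2 of the 3 values shown sit.

The compounds shown leave open whether the loss follows the arrival of the chlorine, the departure of the methyl, or the new place of the substituent on the phenyl ring, since this one step changes all three together. Going by these compounds, a plain phenyl or a 2-chlorophenyl on the same nitrogen, with the rest of compound 1 kept, would pull these apart, and it also remains open whether any group at this position can give a lower number than compound 1 does.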